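Swapping a Fluorophenyl Amide for an Acetamide

The source may hold more compounds than are shown below. What is called first, only, known or untested is meant among the compounds shown, and "the series" means these compounds.

Measured compounds in an assay for binding affinity to 5-hydroxytryptamine receptor 1F (Homo sapiens), read by radioligand binding; on this read-out higher numbers stand for weaker inhibition and lower numbers for stronger inhibition:
Compound 1, `CN1CCC(c2c[nH]c3cnc(NC(=O)c4ccc(F)cc4)cc23)CC1`: 13 nM
Compound 2, `CC(=O)Nc1cc2c(C3CCN(C)CC3)c[nH]c2cn1`: 210 nM
Compound 3, `O=C(Nc1ccc2[nH]cc(C3CCNCC3)c2n1)c1ccc(F)cc1`: 9.5 nM

Compounds 1 and 2 share a core and differ in a single spot: methyl in place of 4-fluorophenyl on a carbonyl carbon. That one change gave a 16-fold higher number from compound 1 to compound 2 (1.21 log units; beyond the scatter), so the smaller amide is clearly the weaker binder of the two on this read-out.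

Compound 3 carries a different core; how its core differs from that of compound 1 is not broken down here. Its value and that of compound 1 lie within the scatter of one another, so the two cannot be ordered on this evidence, while compound 2 sits well apart from both.

Compound 4 `CC(=O)Nc1ccc2[nH]cc(C3CCNCC3)c2n1` has not yet been measured. It is related to compound 3 by methyl in place of 4-fluorophenyl on a carbonyl carbon, the same change, at the same place, that links compound 1 to compound 2. Going by the values given here, with only one earlier example, the expectation is that this change on the core of compound 3 behaves much as it did on the core of compound 1: compound 4 is expected to show a 16-fold higher number from compound 3 to compound 4 (1.20 log units; beyond the scatter), resting on compound 1 to compound 2 having given a 16-fold higher number from compound 1 to compound 2 (1.21 log units; beyond the scatter). On that basis, the estimated value for compound 4 in this assay is 150 nM, with a plausible range from 50 nM to 450 nM.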

Compound 4, inhibition constant: 45 nM
For compound 4 the middle estimate is 3.3-fold (0.52 log units) above the measured one, outside the stated range (below it).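

Replacing 4-fluorophenyl with methyl on the carbonyl carbon weakened binding once more in this assay, with a 4.7-fold higher number from compound 3 to compound 4 (0.68 log units; beyond the scatter), so the direction of the change held when it moved from the core of compound 1 to the core of compound 3. The size of the change did not hold, so a step measured on one core was not a reliable guide to how large the same step would be on the other, and the core matters to the outcome here: the same change on two cores in this assay, a 16-fold higher number (1.21 log units; beyond the scatter) from compound 1 to compound 2 and a 4.7-fold higher number (0.68 log units; beyond the scatter) from compound 3 to compound 4, 3.4-fold (0.53 log units) apart, beyond the scatter of two such steps

These two pairs do not show which difference between the two cores lies behind that gap, and they cannot say whether the change would keep its direction or its size on a third core.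

The compounds shown also leave open how other groups on the same carbonyl carbon would behave, since only 4-fluorophenyl and methyl appear there, and a plain phenyl without the fluorine or a longer chain such as propyl would be informative. Each of these, placed on both cores, would show whether the two cores still respond differently once the group on the carbonyl carbon is something other than methyl.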